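Replacing thiophen-2-yl with phenyl at compound 3

The source may report more compounds than this note shows. Statements on the series, on what has been measured and on what is new or still open speak of the compounds shown alone.

For the measured compounds named here, in a functional assay on A2780 cells (Homo sapiens) for antiproliferative activity, read by fluorescence, with a stated time of 72 h (a higher number here means a weaker inhibitor, a lower number a stronger inhibitor), compound 3 `CN1CCC(C(=O)N2Cc3c(NC(=O)c4cccs4)n[nH]c3C2(C)C)CC1` gives 30 nM, the lowest number measured so far. Compound 2 `CC1(C)c2[nH]nc(NC(=O)c3ccc(F)cc3)c2CN1C(=O)C1CCN(C2CC2)CC1` gives 380 nM. Compound 1 `CC(=O)N1CCN(C(=O)N2Cc3c(NC(=O)c4ccc(F)cc4)n[nH]c3C2(C)C)CC1` gives > 10000 nM, which is a limit and not a number. Compound 4 `CN1CCC(C(=O)N2Cc3c(NC(=O)c4ccccc4)n[nH]c3C2(C)C)CC1` carries phenyl in place of thiophen-2-yl on a carbonyl carbon. Going by the values given here, the only measured step, an at least 26-fold lower number from compound 1 to compound 2 (1.42 log units; beyond the scatter), is large but replaces 4-acetylpiperazin-1-yl with 1-cyclopropylpiperidin-4-yl elsewhere, so it bears only weakly on this change. Among the compounds with values here, no measured step isolates the change itself. A modest shift in this assay toward a higher number is expected, estimated as a 2.3-fold higher number from compound 3 to compound 4 (0.37 log units; beyond the scatter). For compound 4 the estimated value is 70 nM, with an expected range of 20 nM to 300 nM.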

Compound 4, half-maximal inhibitory concentration: 160 nM
For compound 4 the middle estimate is 2.3-fold (0.36 log units) below the measured one; measured number inside the range.
By their numbers in this assay, from the lowest: compound 3; then compound 4; then compound 2. At a limit, above all of these: compound 1.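

With the rest of the structure unchanged, this assay gives the only listed step at this carbonyl carbon: a 5.3-fold higher number from compound 3 to compound 4 (0.73 log units; beyond the scatter). For the compounds shown here, the only earlier step concerned the other carbonyl substituent, so this one shows that the group on this carbonyl carbon also moves the number, with thiophen-2-yl giving the lower value of this pair. Nothing at hand bears on why this step occurs.

Still open, on these data alone, is how furan-2-yl, pyridin-3-yl or cyclohexyl would read here. The effect of a fluorine on the phenyl ring also remains unisolated.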